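Chloro for Bromo on the Shared Core

The source may report more compounds than this note shows. Statements on the series, on what has been measured and on what is new or still open speak of the compounds shown alone.

Of the compounds shown here, three built on one shared core have been tested in a functional assay on BGC-823 cells (Homo sapiens) for inhibition, read by CCK-8 assay, with a stated time of 48 h; a higher number here means a weaker inhibitor, a lower number a stronger inhibitor. Compound 1 `O=C1CSC(N2N=C(c3ccc(Br)cc3)CC2c2ccc3ccccc3c2)=N1` gives 11700 nM. Compound 2 `Brc1ccc(C2=NN(C3=NC(c4ccccc4)CS3)C(c3ccc4ccccc4c3)C2)cc1` gives 13000 nM, and compound 3 `Brc1ccc(C2=NN(C3=NC(c4ccccc4)CS3)C(c3cccc4ccccc34)C2)cc1` gives 17400 nM. Among these three numbers compound 2 stands second highest, with compound 1 nearest and compound 3 furthest, and both of those sit within the scatter of it. The two measured steps are small: a 1.1-fold higher number from compound 1 to compound 2 (0.05 log units; within the scatter) and a 1.3-fold higher number from compound 2 to compound 3 (0.13 log units; within the scatter). Neither of them touches the ring that carries the bromine.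

Compound 4 `Clc1ccc(C2=NN(C3=NC(c4ccccc4)CS3)C(c3ccc4ccccc4c3)C2)cc1` has not yet been measured. It differs from compound 2 in one place: chloro in place of bromo on an aromatic carbon. Within the data shown here, no measured step changes this halogen, so nothing in the three numbers speaks for or against a change there; the only guide is that every step seen so far, whether a ring system was exchanged on the amine nitrogen or on the saturated ring carbon, stayed within the scatter. For compound 4 the expected step is therefore no larger than those, with no direction beyond the scatter, a 1.1-fold higher number from compound 2 to compound 4 (0.03 log units; within the scatter). For compound 4 in this assay the estimate is 14000 nM, expected to fall between 7000 nM and 28000 nM.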

Compound 4, half-maximal inhibitory concentration: 14600 nM
Compound 4: the middle estimate sits 1.0-fold (0.02 log units) below what was measured; low and high end bracket the measured number.
By their numbers in this assay, from the lowest: compounds 1, 2, 4 and 3 (each within the scatter of the next).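

Among these compounds, this is the first look at the halogen itself: in this assay the exchange of 4-bromophenyl for 4-chlorophenyl gives a 1.1-fold higher number from compound 2 to compound 4 (0.05 log units; within the scatter) and so cannot be told apart from no effect at all. At this aromatic carbon, para to a large group, the bromine is therefore not needed to keep the number where it stands, as chlorine serves equally well in this assay. With this step, changes at three places on the shared core have been seen, and all of them lie within the scatter, although the numbers for all four compounds stay in the same range and none of the changes separates one compound from another. Nothing available here bears on why this exchange makes so little difference.

On these data alone, only two halogens have been compared at this position, so it remains open what a plain hydrogen, a methoxy group, a nitrile or a carboxylic acid would do there. As far as these compounds go, it is also open whether chloro in place of bromo would read the same way on the core of compound 1 or alongside the naphthalen-1-yl group of compound 3.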